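Returning to a 3-substituted phenyl: an expectation for compound 4

The compounds below may be only part of what the source reports. "The series", "measured", "known", "first", "only" and "open" are said of these compounds alone.

Compound 1 `C[C@H](c1ccc(C(=O)NCCC(=O)O)cc1)N1C(=O)C(c2cccc(C3CC3)c2)=N[C@]12CC[C@@H](C(C)(C)C)CC2`: in an assay on membranes from liver for displacement of a labelled ligand from Glucagon receptor (Mus musculus), read by scintillation counting, with a stated time of 60 min (a higher number here means a weaker inhibitor, a lower number a stronger inhibitor), compound 1 gives 1700 nM.
Compound 2 `C[C@H](c1ccc(C(=O)NCCC(=O)O)cc1)N1C(=O)C(c2cccc(F)c2)=N[C@]12CC[C@@H](C(C)(C)C)CC2`: in this assay compound 2 gives 4400 nM.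
Compound 3 `C[C@H](c1ccc(C(=O)NCCC(=O)O)cc1)N1C(=O)C(c2ccccc2F)=N[C@]12CC[C@@H](C(C)(C)C)CC2`: in this assay compound 3 gives > 10000 nM, which is a limit of the assay and not a number.

Compound 3 is the weakest of the three, as the steps of an at least 5.8-fold higher number from compound 1 to compound 3 (0.76 log units; beyond the scatter) and an at least 2.2-fold higher number from compound 2 to compound 3 (0.35 log units; beyond the scatter) show. Compound 4 `C[C@H](c1ccc(C(=O)NCCC(=O)O)cc1)N1C(=O)C(c2cccc(OC(F)(F)F)c2)=N[C@]12CC[C@@H](C(C)(C)C)CC2` differs from compound 3 by 3-(trifluoromethoxy)phenyl in place of 2-fluorophenyl on a carbon with a double bond to nitrogen. Both 3-substituted phenyls gave measurable numbers, and the step of a 2.6-fold higher number from compound 1 to compound 2 (0.41 log units; beyond the scatter) shows they differ only modestly from each other. Compound 4, with a 3-substituted phenyl again, is therefore expected to move back toward those values, a step of an at least 4.0-fold lower number from compound 3 to compound 4 (0.60 log units; beyond the scatter). In this assay compound 4 is estimated at 2500 nM, with a range from 1000 nM to 7000 nM.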

Compound 4, half-maximal inhibitory concentration: 1500 nM
For compound 4 the middle estimate is 1.7-fold (0.22 log units) above the measured one, within the range that was stated.
By their numbers in this assay, from the lowest: compounds 4 and 1 (each within the scatter of the next); then compound 2. At a limit, above all of these: compound 3.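

Replacing 2-fluorophenyl with 3-(trifluoromethoxy)phenyl gives an at least 6.6-fold lower number from compound 3 to compound 4 (0.82 log units; beyond the scatter), so this change at the carbon with a double bond to nitrogen restores a measurable number. The reading for compound 3 is a limit and not a number: the limit of > 10000 nM in this assay, at which 1 of the 4 values shown sits. The group on the 3-substituted phenyl also matters, since trifluoromethoxy in place of fluoro gives a 2.9-fold lower number from compound 2 to compound 4 (0.47 log units; beyond the scatter), whereas trifluoromethoxy in place of cyclopropyl gives a 1.1-fold lower number from compound 1 to compound 4 (0.05 log units; within the scatter), which leaves compound 1 and compound 4 indistinguishable.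

Still open, from the compounds shown here alone, is how a phenyl carrying an amine or a carboxylic acid in place of trifluoromethoxy would read, and whether 2-(trifluoromethoxy)phenyl would behave like 2-fluorophenyl.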